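This account rests on a few compounds, and the source may have more. Where it says the series, first, only, none or still open, it means among the compounds named here.

Compound 1 `COc1ccc(-n2nncc2CN2C(=O)C3(C(C#N)=C(N)Oc4c3c3nc5ccccc5nc3c3ccccc43)c3ccccc32)cc1` gives, in a functional assay on MCF7 cells (Homo sapiens) for antiproliferative activity, read by MTT assay, with a stated time of 48 h (on this read-out lower numbers stand for stronger inhibition and higher numbers for weaker inhibition), only a limit: > 50000 nM.
Compound 2 `CCOc1ccc(-n2nncc2CN2C(=O)C3(C(C#N)=C(N)Oc4c3c3nc5ccccc5nc3c3ccccc43)c3ccccc32)cc1` gives in this assay only a limit: > 50000 nM.
Compound 3 `Cc1ccc(-n2nncc2CN2C(=O)C3(C(C#N)=C(N)Oc4c3c3nc5ccccc5nc3c3ccccc43)c3ccccc32)c(C)c1` gives in this assay only a limit: > 50000 nM.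

All three measured compounds share one core and differ only in the aryl group carried on an aromatic nitrogen. For compound 3 the number in this assay is a limit, not a value, and the same holds for the other two, so that the limit of > 50000 nM in this assay, at which 3 of the 3 values shown sit, is the whole picture so far. The steps between them, a step that the two limits leave unreadable from compound 1 to compound 2, a step that the two limits leave unreadable from compound 1 to compound 3 and a step that the two limits leave unreadable from compound 2 to compound 3, cannot be read in size or direction, since a limit sits at both ends.

Compound 4 `N#CC1=C(N)Oc2c(c3nc4ccccc4nc3c3ccccc23)C12C(=O)N(Cc1cnnn1-c1cc(Cl)ccc1Cl)c1ccccc12` is not yet measured. It differs from compound 3 in the same place as the earlier changes: 2,5-dichlorophenyl in place of 2,4-dimethylphenyl on an aromatic nitrogen. The two steps that alter this aryl group, from compound 1 and from compound 2 to compound 3, both stay at the limit, so no direction can be drawn from them. Compound 4 is therefore expected to give 60000 nM, within 15000 nM to 250000 nM, most likely again as a limit, and the expected step that the limit leaves unreadable from compound 3 to compound 4 is none beyond the scatter.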

Compound 4, half-maximal inhibitory concentration: > 50000 nM
Compound 4: no number, only a limit (the forecaster's own chance of this, stated with the estimate: 85%); the middle value is on the limit's open side.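

Compound 4 gives only a limit, as do compound 1, compound 2 and compound 3, so none of the steps to compound 4 can be read in size or direction. Going by these compounds, whether any aryl group at this place can give a measurable value in this assay remains open.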